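Methylating a Phenolic Hydroxyl on a Flavone Core

The source may hold more compounds than are shown below. What is called first, only, known or untested is meant among the compounds shown, and "the series" means these compounds.

Four compounds share a flavone-type scaffold and are compared in a functional assay on A549 cells (Homo sapiens) for cytotoxicity, read by MTT assay, with a stated time of 6 days; on this read-out higher numbers stand for an effect only at larger amounts of compound and lower numbers for an effect already at smaller amounts. Compound 1 `COC(=O)c1c(-c2ccc(OC)cc2)oc2ccccc2c1=O` and compound 2 `COC(=O)c1c(-c2ccc(O)cc2)oc2ccccc2c1=O` differ only by methyl in place of hydrogen on an oxygen on an aromatic ring. In this assay compound 1 gives only a limit, > 25 ug/mL. Compound 2 likewise gives only a limit, > 25 ug/mL. Because both values sit at the limit of > 25 ug/mL in this assay, at which 2 of the 3 values shown sit, the step that the two limits leave unreadable from compound 2 to compound 1 cannot be read, and no conclusion about the effect of this change can be drawn from that pair.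

Compound 3 `COc1cc(-c2cc(=O)c3cc(O)ccc3o2)cc(OC)c1OC` belongs to a different core; how its core differs from that of compound 2 is not broken down here. In this assay, within the data shown here, compound 3 gives 9.82 ug/mL, the only full number among the three measured compounds.

Compound 4 `COc1ccc2oc(-c3cc(OC)c(OC)c(OC)c3)cc(=O)c2c1` is not yet measured. It differs from compound 3 by methyl in place of hydrogen on an oxygen on an aromatic ring, the same change as that from compound 2 to compound 1, at the same kind of place. Among the measured compounds shown here, the only measured example of this change cannot be read from the pair of compound 2 and compound 1, so the expectation rests on compound 3 alone and its value 9.82 ug/mL. Compound 4 is expected to give about 12 ug/mL, with a likely range from 5 ug/mL to 28 ug/mL; the estimated step of a 1.2-fold higher number from compound 3 to compound 4 (0.09 log units; within the scatter) is taken to lie within the usual scatter.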

Compound 4, concentration for half-maximal effect: > 25 ug/mL
Compound 4: only a limit was reported (the forecaster's own chance of this, stated with the estimate: 25%); middle value at least 2.0-fold (0.31 log units) away from the limit.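

On the core of compound 3, replacing hydroxy with methoxy gives in this assay an at least 2.5-fold higher number from compound 3 to compound 4 (0.40 log units; beyond the scatter), so on this core the methoxy compound needs a larger amount of compound for the same effect. Compound 4 gives > 25 ug/mL, which is a limit of the assay and not a number. Among these compounds, this single pair does not show that the change acts the same way on another core, since the only other example, from compound 2 to compound 1 on a different core, cannot be read: the limit of > 25 ug/mL in this assay, at which 3 of the 4 values shown sit.

From the compounds shown here alone, it remains open whether the hydroxy of compound 3 could be replaced by an amine or a carboxylic acid, or its hydrogen by a longer chain such as ethyl, with a full number still obtained in this assay. Going by these compounds, it is also open whether any such group would bring the core of compound 2 to a full number, which would give a readable second comparison.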